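Moving the methoxy group from compound 3 to compound 4

This account rests on a few compounds, and the source may have more. Where it says the series, first, only, none or still open, it means among the compounds named here.

Values measured in a functional assay on HepG2 cells (Homo sapiens) for cytotoxicity, read by MTT assay, with a stated time of 48 h (a lower number here means a stronger inhibitor, a higher number a weaker inhibitor), for three compounds follow.
Compound 1 `Cc1ncc([N+](=O)[O-])n1CCSc1nnc(-c2ccccc2)o1` gives 17500 nM
Compound 2 `Cc1ccccc1-c1nnc(SCCn2c([N+](=O)[O-])cnc2C)o1` gives 5100 nM
Compound 3 `COc1ccccc1-c1nnc(SCCn2c([N+](=O)[O-])cnc2C)o1` gives 10000 nM

Compound 3 stands within the scatter of both other compounds, as the steps (a 1.8-fold lower number from compound 1 to compound 3 (0.24 log units; within the scatter)) and (a 2.0-fold higher number from compound 2 to compound 3 (0.29 log units; within the scatter)) show. Only the methyl step (a 3.4-fold lower number from compound 1 to compound 2 (0.54 log units; beyond the scatter)) goes beyond the scatter. Compound 4 `COc1ccc(-c2nnc(SCCn3c([N+](=O)[O-])cnc3C)o2)cc1` keeps the rest of compound 3 but carries 4-methoxyphenyl in place of 2-methoxyphenyl on an aromatic carbon of a five-membered aromatic ring with 2 nitrogen and 1 oxygen (4-methoxyphenyl in place of 2-methoxyphenyl on an aromatic carbon). No measurement compares the two methoxyphenyl groups directly. The nearest guide is methoxy in place of hydrogen (a 1.8-fold lower number from compound 1 to compound 3 (0.24 log units; within the scatter)), so only a small step is expected in this assay and no firm direction. The estimated step (a 1.1-fold lower number from compound 3 to compound 4 (0.05 log units; within the scatter)) stays within the scatter. Compound 4 is expected at 9000 nM with an estimated range from 3500 nM to 22000 nM in this measurement.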

Compound 4, half-maximal inhibitory concentration: 5800 nM
Compound 4: the middle estimate sits 1.6-fold (0.19 log units) above what was measured, within the range that was stated.
By their numbers in this assay, from the lowest: compounds 2, 4, 3 and 1 (each within the scatter of the next, the first and the last beyond it).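

In this assay, 4-methoxyphenyl in place of 2-methoxyphenyl on this aromatic carbon leaves the two compounds within the scatter (a 1.7-fold lower number from compound 3 to compound 4 (0.24 log units; within the scatter)), so the assay does not separate these two placements of the methoxy group. Compound 4 also stands level with the 2-methylphenyl compound (a 1.1-fold higher number from compound 2 to compound 4 (0.06 log units; within the scatter)), and, unlike the step to compound 3 (a 1.8-fold lower number from compound 1 to compound 3 (0.24 log units; within the scatter)), its step from the unsubstituted phenyl compound goes beyond the scatter (a 3.0-fold lower number from compound 1 to compound 4 (0.48 log units; beyond the scatter)), which gives the first methoxy compound clearly apart from compound 1. No measured evidence accounts for any of these steps.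

The compounds shown leave open how a group other than methoxy would behave on the same phenyl ring, such as an amine or a carboxylic acid in place of the methoxy of compound 4. They also leave open whether 4-methylphenyl would stand level with compound 2.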